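The source may hold more compounds than are shown below. What is called first, only, known or untested is meant among the compounds shown, and "the series" means these compounds.

Of the compounds shown here, three have been measured in a functional assay on CHO cells for agonist activity at Free fatty acid receptor 1 (Homo sapiens), read by calcium flux; on this read-out lower numbers stand for an effect already at smaller amounts and higher numbers for an effect only at larger amounts of compound. Compound 1 `O=C(O)CCc1nnc(C(=O)Nc2cccc(-c3ccc(F)cc3)c2)s1` gives 1280 nM, compound 2 `O=C(O)CCc1nnc(C(=O)Nc2cccc(-c3ccco3)c2)s1` gives 1640 nM, and compound 3 `O=C(O)CCc1ccc(OCc2nnc(C(=O)Nc3ccccc3F)s2)cc1` gives 580 nM. Compound 3 therefore stands at the lowest of the three numbers; compound 1 is its nearest neighbour and compound 2 its furthest, and both of those gaps lie beyond the scatter. Within the data shown here, the only single-point step among the measured compounds, a 1.3-fold higher number from compound 1 to compound 2 (0.11 log units; within the scatter), concerns the aryl group at the far end of the anilide and stays within the scatter.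

Compound 4 `Cc1ccccc1NC(=O)c1nnc(COc2ccc(CCC(=O)O)cc2)s1` differs from compound 3 in one place: methyl in place of fluoro on an aromatic carbon. Among the measured compounds shown here, no measured step exchanges a substituent on the anilide ring itself, so the step from compound 1 to compound 2 is the only guide, and it bears on the question only loosely: it shows that a change at the anilide end of the shared core left the number within the scatter. Compound 4 is accordingly expected to remain close to compound 3. The expected step is a 1.1-fold higher number from compound 3 to compound 4 (0.05 log units; within the scatter), not beyond the scatter in either direction. For compound 4 the estimate in this assay is 650 nM, with a range from 250 nM to 1700 nM.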

Compound 4, half-maximal effective concentration: 1520 nM
Compound 4: the middle estimate sits 2.3-fold (0.37 log units) below what was measured; low and high end bracket the measured number.
By their numbers in this assay, from the lowest: compound 3; then compounds 1, 4 and 2 (each within the scatter of the next).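

In this assay, exchanging fluoro for methyl on an aromatic carbon ortho to a large group gives a 2.6-fold higher number from compound 3 to compound 4 (0.42 log units; beyond the scatter), so this place responds to a swap of one heavy atom for one other heavy atom. Among these compounds, the only earlier single-point step, a 1.3-fold higher number from compound 1 to compound 2 (0.11 log units; within the scatter), concerned a different place and a larger group, and it showed no change that could be told from the scatter, whereas this step shows a difference beyond the scatter, with the fluoro compound holding the lower number. The two groups have the same count of heavy atoms, and neither adds a hydrogen-bond donor, acceptor or net charge, so those counts do not separate them, and no supporting measurement is available to explain the step.

The compounds shown leave open how hydrogen, chloro or methoxy at this place would stand against fluoro and methyl, so these two groups mark only two points and no trend. They also leave open whether the exchange of fluoro for methyl would produce a step of similar size at another carbon of this ring, or with the propanoic acid chain and the rest of the shared core altered.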